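From fluoro to hydroxy on a shared core

The source may report more compounds than this note shows. Statements on the series, on what has been measured and on what is new or still open speak of the compounds shown alone.

In a functional assay on A-431 cells (Homo sapiens) for antiproliferative activity, read by sulforhodamine B assay, with a stated time of 72 h (a lower number here means a stronger inhibitor, a higher number a weaker inhibitor), compound 1 `C=C1CC(CBr)(c2ccccc2)OC1=O` gives 1480 nM and compound 2 `C=C1CC(CBr)(c2ccc(C(F)(F)F)cc2)OC1=O` gives 1010 nM. Trifluoromethyl in place of hydrogen on an aromatic carbon accounts for a 1.5-fold lower number from compound 1 to compound 2 (0.17 log units; within the scatter). Compound 3 `C=C1CC(CF)(c2ccccc2)OC1=O` stands at 25100 nM, the highest of the three numbers and so the weakest inhibitor of the set. It comes from fluoro in place of bromo on a saturated chain carbon bound to a saturated ring carbon, a large change amounting to a 17-fold higher number from compound 1 to compound 3 (1.23 log units; beyond the scatter).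

Compound 4 `C=C1CC(CO)(c2ccccc2)OC1=O` has not yet been measured. It differs from compound 3 by hydroxy in place of fluoro on a saturated chain carbon bound to a saturated ring carbon, with hydroxy in place of fluoro at that same carbon. Only the bromo-to-fluoro step touches this place, whereas the trifluoromethyl step lies elsewhere and is small. For the measured compounds named here, no measured compound carries hydroxy, so the data give no direct guide to this exchange. Neither compound 3 nor compound 4 keeps the bromo of compound 1, which gives 1480 nM, so a return to that level is not expected. No change beyond the scatter is expected in this assay, and the expected step is a 1.3-fold lower number from compound 3 to compound 4 (0.10 log units; within the scatter). The estimate for compound 4 is 20000 nM, with an expected range from 6000 nM to 60000 nM.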

Compound 4, half-maximal inhibitory concentration: 4060 nM
For compound 4 the middle estimate is 4.9-fold (0.69 log units) above the measured one; measured number outside the range, below it.
By their numbers in this assay, from the lowest: compounds 2 and 1 (each within the scatter of the next); then compound 4; then compound 3.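

In this assay the saturated chain carbon bound to a saturated ring carbon proves more graded than the bromo-to-fluoro exchange alone suggested: hydroxy in place of fluoro gives a 6.2-fold lower number from compound 3 to compound 4 (0.79 log units; beyond the scatter) and so recovers part of the large loss seen with fluoro. Recovery is only partial, since hydroxy in place of bromo gives a 2.7-fold higher number from compound 1 to compound 4 (0.44 log units; beyond the scatter) and leaves compound 4 short of the level of compound 1. With every step among them beyond the scatter, compound 1, compound 4 and compound 3 show that bromo, hydroxy and fluoro at this place give three separate levels on the shared core, so losing bromo does not by itself fix the number at the level of compound 3. Nothing available gives a reason for this order of the three groups.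

The compounds shown leave open whether an amine or a methoxy group at this same place would fall closer to bromo or to fluoro, and whether a longer chain carrying hydroxy would hold the level of compound 4. They also leave open whether trifluoromethyl on the aromatic carbon, whose step lies within the scatter with bromo in place, would behave the same way with hydroxy there.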